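A few compounds are considered here, and "the series" means these few. Any claim that something is new, unique, unknown or untested is made for them only; others in the source may bear on it.

In a functional assay for inhibition, with a stated time of 30 min, tested at 1 mM (on this read-out lower numbers stand for less inhibition and higher numbers for more inhibition at the one concentration tested (going by the name of the read-out)), compound 1, whose structure is `COc1cc(/C(Cl)=C/C=C(\C#N)C(=O)c2c[nH]c3ccccc23)cc(OC)c1OC`, gives 21.1%. Compound 2, `COc1cc(/C(Cl)=C/C=C(\C#N)C(=O)c2c[nH]c3ccc(Br)cc23)cc(OC)c1OC`, carries the change (bromo in place of hydrogen on an aromatic carbon), and in this assay compound 2 gives 26.3%, a step of a number 5.2 percentage points higher from compound 1 to compound 2 (within the scatter). Compound 3, `COc1ccc(/C(Cl)=C/C=C(\C#N)C(=O)c2c[nH]c3ccccc23)cc1OC`, differs from compound 1 in its core by hydrogen in place of methoxy on an aromatic carbon; in this assay compound 3 gives 15.8%, a step of a number 5.3 percentage points lower from compound 1 to compound 3 (within the scatter). Compound 4, `COc1ccc(/C(Cl)=C/C=C(\C#N)C(=O)c2c[nH]c3ccc(Br)cc23)cc1OC`, is not yet measured; it stands to compound 3 as compound 2 stands to compound 1, through the change (bromo in place of hydrogen on an aromatic carbon), the same change as before. The step is expected to be a number 5.2 percentage points higher from compound 3 to compound 4 (within the scatter), because the earlier one measured a number 5.2 percentage points higher from compound 1 to compound 2 (within the scatter) and nothing else is known of this change. For compound 4 in this assay a value of about 21% is therefore expected, between 8% and 34%.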

Compound 4, a percentage reported as inhibition, at one concentration (the size of the read-out at that concentration, not a potency): 11.8%
Compound 4: the middle estimate sits 9.2 percentage points above what was measured; the measured number falls inside the stated range.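

In this assay, bromo in place of hydrogen on an aromatic carbon gives a step of a number 4 percentage points lower from compound 3 to compound 4 (within the scatter), and this does not differ measurably from the same change on the core of compound 1: the same change on two cores in this assay, a number 5.2 percentage points higher (within the scatter) from compound 1 to compound 2 and a number 4 percentage points lower (within the scatter) from compound 3 to compound 4, 9.2 percentage points apart, within the scatter of two such steps. Hydrogen in place of methoxy gives a step of a number 14.5 percentage points lower from compound 2 to compound 4 (beyond the scatter), which also cannot be told apart from its earlier counterpart: the same change on two cores in this assay, a number 5.3 percentage points lower (within the scatter) from compound 1 to compound 3 and a number 14.5 percentage points lower (beyond the scatter) from compound 2 to compound 4, 9.2 percentage points apart, within the scatter of two such steps. Both changes therefore carry between these cores within the scatter, but with one pair of steps each, this does not establish that either change behaves alike across the wider series.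

The compounds shown leave open how an amine or a carboxylic acid would read in place of the bromo. They also leave open what a longer chain would do in place of a methoxy group.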